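The source may hold more compounds than are shown below. What is called first, only, known or untested is meant among the compounds shown, and "the series" means these compounds.

Compound 1 `CC(=O)Nc1ccc(O)c(C(=O)/C=C/c2ccccc2)c1` and compound 2 `COc1ccccc1/C=C/C(=O)c1cc(NC(C)=O)ccc1O` share one core, while compound 3 `CC(=O)Nc1ccc2oc(-c3ccccc3)cc(=O)c2c1` and compound 4 `COc1cccc(-c2cc(=O)c3cc(NC(C)=O)ccc3o2)c1` share another; the difference between the two cores is not broken down here. In an ADME assay on THP-1 cells (Homo sapiens) for cytotoxicity, read by flow cytometry and propidium iodide staining, with a stated time of 72 h (on this read-out lower numbers stand for stronger inhibition and higher numbers for weaker inhibition), compound 1 gives 85500 nM. Compound 2 reaches only the limit of the assay, > 125000 nM, so no number is recorded for it. The change separating these two is methoxy in place of hydrogen on an aromatic carbon and its size is an at least 1.4-fold higher number from compound 1 to compound 2 (0.16 log units; that floor lies within the scatter). Compound 3, measured in this assay, gives 97000 nM, which sits within the usual scatter of the value of compound 1. Compound 4 differs from compound 3 by methoxy in place of hydrogen on an aromatic carbon, the same kind of change as that from compound 1 to compound 2, though here the methoxy sits meta to a large group where before it sat ortho to a large group. Because the earlier step was an at least 1.4-fold higher number from compound 1 to compound 2 (0.16 log units; that floor lies within the scatter), compound 4 is expected to shift by roughly a 1.3-fold higher number from compound 3 to compound 4 (0.13 log units; within the scatter). Compound 4 is accordingly estimated at 130000 nM, spanning 80000 nM to 250000 nM. A limit result is also plausible given (the limit of > 125000 nM in this assay, at which 1 of the 3 values shown sits).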

Compound 4, half-maximal inhibitory concentration: 10000 nM
Beside the measured number, compound 4's estimate is 13-fold (1.11 log units) above it; measured number outside the range, below it.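

In this assay, methoxy in place of hydrogen on an aromatic carbon brings a 9.7-fold lower number from compound 3 to compound 4 (0.99 log units; beyond the scatter), so compound 4 stands apart from compound 3 by more than the usual scatter. The change therefore does not carry over from the core of compound 1 to the core of compound 3 with the same outcome in this assay: the same change on two cores in this assay, an at least 1.4-fold higher number (0.16 log units; that floor lies within the scatter) from compound 1 to compound 2 and a 9.7-fold lower number (0.99 log units; beyond the scatter) from compound 3 to compound 4, at least 14-fold (1.15 log units) apart, beyond the scatter of two such steps

This does not show whether the core or the place of the methoxy, meta to a large group in compound 4 but not in compound 2, sets the two steps apart, and the earlier step rests on a limit rather than a number: the limit of > 125000 nM in this assay, at which 1 of the 4 values shown sits.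

Open, on these data alone, is what a methoxy meta to a large group would do on the core of compound 1, and what a methoxy in the place it holds in compound 2 would do on the core of compound 3. Also open, as far as these compounds go, is whether a hydroxyl, a fluorine or an amine at the place of the methoxy in compound 4 would shift the number in the same way.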